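The source may hold more compounds than are shown below. What is called first, only, known or untested is meant among the compounds shown, and "the series" means these compounds.

Working notes on the series:
- Compound 1 `COc1cccc(OC)c1C(=O)Nc1c[nH]nc1C(=O)N[C@H]1CC[C@H](OC)CC1`: 31000 nM
- Compound 2 `COc1cccc(OC)c1C(=O)Nc1c[nH]nc1C(=O)NCCCOC(C)C`: > 50000 nM (a limit)
- Compound 3 `COc1cccc(OC)c1C(=O)Nc1c[nH]nc1C(=O)NCc1ncccc1C`: > 50000 nM (a limit)
- Compound 4 `COc1cccc(OC)c1C(=O)Nc1c[nH]nc1C(=O)NC1CCCCC1`: not yet measured

In an ADME assay on MRC5 cells (Homo sapiens) for inhibition, with a stated time of 72 h (a lower number here means that less compound is needed, a higher number that more compound is needed for the effect), compound 3 gives > 50000 nM, which is a limit and not a number. This is the limit of > 50000 nM in this assay, at which 2 of the 3 values shown sit. Its true position is therefore unknown, and only compound 1 has a numerical value.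

The next step is cyclohexyl in place of (3-methylpyridin-2-yl)methyl on an amide-type nitrogen, with cyclohexyl in place of (3-methylpyridin-2-yl)methyl on an amide-type nitrogen. The closest measured change is an at least 1.6-fold higher number from compound 1 to compound 3 (0.20 log units; that floor lies within the scatter), which links the same (3-methylpyridin-2-yl)methyl to the 4-methoxycyclohexyl of compound 1. The change to the chain shows a floor of the same size: an at least 1.6-fold higher number from compound 1 to compound 2 (0.20 log units; that floor lies within the scatter). The remaining pair shows a step that the two limits leave unreadable from compound 2 to compound 3, so it offers no guidance.

Cyclohexyl is the nearest match to 4-methoxycyclohexyl, so compound 4 is expected to read close to compound 1, which gives 31000 nM. The expected change is an at least 1.6-fold lower number from compound 3 to compound 4 (0.22 log units; that floor lies within the scatter), towards a lower number but of poorly defined size, and a further limit remains possible. The estimate for compound 4 is 30000 nM, with an expected range of 12000 nM to 60000 nM.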

Compound 4, half-maximal effective concentration: 35000 nM
Beside the measured number, compound 4's estimate is 1.2-fold (0.07 log units) below it; the measured number falls inside the stated range.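

In this assay, for the compounds shown here, hydrogen in place of methoxy on a saturated ring carbon gives a 1.1-fold higher number from compound 1 to compound 4 (0.05 log units; within the scatter); this is the first pair with two numbers, and it shows that the methoxy group can go without a readable change in this assay. Cyclohexyl in place of (3-methylpyridin-2-yl)methyl on the amide-type nitrogen gives an at least 1.4-fold lower number from compound 3 to compound 4 (0.15 log units; that floor lies within the scatter), and cyclohexyl in place of 3-isopropoxypropyl gives an at least 1.4-fold lower number from compound 2 to compound 4 (0.15 log units; that floor lies within the scatter), and neither floor sets cyclohexyl apart from those two groups. Compound 2 and compound 3 each carry a limit and not a number, and these two steps therefore stay floors: the limit of > 50000 nM in this assay, at which 2 of the 4 values shown sit.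

On these data alone, with numbers for compound 1 and compound 4 only, the true size of any difference between the two cyclohexyl-type groups and the other two groups on this nitrogen remains open. Also open, as far as these compounds go, is whether an amine or a carboxylic acid on the cyclohexyl ring, or a smaller ring such as cyclopentyl on the same nitrogen, would move the number beyond the scatter.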